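Swapping Hydroxy for Chloro on the Core of Compound 1

A few compounds are considered here, and "the series" means these few. Any claim that something is new, unique, unknown or untested is made for them only; others in the source may bear on it.

Of the compounds shown here, two from this series have numbers so far. Compound 1 `COc1cc2c(/C=C3/C(=O)Nc4ccc(O)cc43)c(Cl)n(Cc3cc(OC)c(OC)c(OC)c3)c2cc1C` gives 2290 nM in a functional assay on cells (Cancer cell lines, Homo sapiens) for cytotoxicity, with a stated time of 48 h (a higher number here means a weaker inhibitor of growth, a lower number a stronger inhibitor of growth), the lowest of the two values. Compound 2 `O=C1Nc2ccccc2/C1=C\c1c(Cl)n(Cc2ccccc2)c2ccccc12` gives 20400 nM in this assay, a weaker result that lies beyond the scatter of the measurement; the two compounds differ in several places, so this gap cannot be tied to one change.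

Compound 3 `COc1cc2c(/C=C3/C(=O)Nc4ccc(Cl)cc43)c(Cl)n(Cc3cc(OC)c(OC)c(OC)c3)c2cc1C` has not yet been measured. It differs from compound 1 in one place: chloro in place of hydroxy on an aromatic carbon. Going by the values given here, no measured pair shows what this exchange alone does to the growth inhibition figure. Among the compounds with values here, with no such step to lean on, the expectation for compound 3 is a small change at most, likely staying within the scatter or drifting slightly toward weaker inhibition, with the step estimated as a 1.4-fold higher number from compound 1 to compound 3 (0.15 log units; within the scatter). The estimated value for compound 3 is 3200 nM, in an expected range from 1000 nM to 10000 nM.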

Compound 3, concentration for 50% growth inhibition: 1780 nM
For compound 3 the middle estimate is 1.8-fold (0.25 log units) above the measured one, within the range that was stated.
By their numbers in this assay, from the lowest: compounds 3 and 1 (each within the scatter of the next); then compound 2.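

In this assay, chloro in place of hydroxy on this aromatic carbon gives a 1.3-fold lower number from compound 1 to compound 3 (0.11 log units; within the scatter), so the two compounds cannot be told apart in this measurement. Going by these compounds alone, this is the first step that changes one place only, and it shows that growth inhibition in this assay holds when the hydrogen-bond donor and acceptor counted for hydroxy are gone, as chloro has neither. Within the data shown here, nothing measured so far says why the two groups read alike.

From the compounds shown here alone, whether an amine, a carboxylic acid or a longer chain such as propoxy on the same carbon would also leave the figure in place remains open. A single exchange at one carbon also says nothing about how changes elsewhere on the shared core would behave.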